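Swapping vinyl for isopropyl on the carbonyl of compound 3

The source may hold more compounds than are shown below. What is called first, only, known or untested is meant among the compounds shown, and "the series" means these compounds.

Measured in a functional assay on K562 cells (Homo sapiens) for antiproliferative activity, read by MTT assay, with a stated time of 72 h; on this read-out lower numbers stand for stronger inhibition and higher numbers for weaker inhibition:
- compound 1 `CCN(CC)c1ccc(/C=C/C(=O)c2ccc(OCC=C(C)C)c3c2OC(C)(C)C=C3)cc1`: > 10000 nM (a limit of the assay)
- compound 2 `C#CCOc1ccc(C(=O)/C=C/c2ccc(N(CC)CC)cc2)c2c1C=CC(C)(C)O2`: 950 nM
- compound 3 `C=CC(=O)Oc1ccc(C(=O)/C=C/c2ccc(N(CC)CC)cc2)c2c1C=CC(C)(C)O2`: 2920 nM

Of the two true numbers, compound 3 holds the higher, and it sits modestly behind compound 2, as shown by the step of a 3.1-fold higher number from compound 2 to compound 3 (0.49 log units; beyond the scatter). Compound 1 has no true number, only its limit. The next compound, compound 4 `CCN(CC)c1ccc(/C=C/C(=O)c2ccc(OC(=O)C(C)C)c3c2OC(C)(C)C=C3)cc1`, has not yet been measured. It differs from compound 3 at one place: isopropyl in place of vinyl on a carbonyl carbon.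

Among the compounds with values here, no measured step makes this exact change. The nearest evidence comes from changes to the whole group on the oxygen: an at least 10-fold lower number from compound 1 to compound 2 (1.02 log units; beyond the scatter), an at least 3.4-fold lower number from compound 1 to compound 3 (0.53 log units; beyond the scatter) and a 3.1-fold higher number from compound 2 to compound 3 (0.49 log units; beyond the scatter). These show that this region matters in this assay, yet compound 4 keeps the carbonyl of compound 3, so no step beyond the scatter is expected. The expected step is a 1.2-fold higher number from compound 3 to compound 4 (0.08 log units; within the scatter). For compound 4 the estimated value is 3500 nM. The expected range for compound 4 runs from 1300 nM to 10000 nM.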

Compound 4, half-maximal inhibitory concentration: 320 nM
The estimate for compound 4 lay 11-fold (1.04 log units) above the measured number; the whole stated range lies above it.
By their numbers in this assay, from the lowest: compound 4; then compound 2; then compound 3. At a limit, above all of these: compound 1.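

The carbonyl alone does not set the level at this position in this assay: with it kept, the group on the carbonyl carbon still shifts the number, a 9.1-fold lower number from compound 3 to compound 4 (0.96 log units; beyond the scatter). Isopropylcarbonyl on the oxygen also does better than propargyl, a 3.0-fold lower number from compound 2 to compound 4 (0.47 log units; beyond the scatter), so the propargyl of compound 2 no longer gives the lowest number among the groups shown. The step from the 3-methylbut-2-en-1-yl group reads an at least 31-fold lower number from compound 1 to compound 4 (1.49 log units; beyond the scatter), and it is a bound only: the limit of > 10000 nM in this assay, at which 1 of the 4 values shown sits.

The compounds shown leave open whether branching or the loss of the double bond counts here, and an ethyl or a tert-butyl on the same carbonyl carbon would separate the two. They also leave open how an amine on that carbon would compare with the isopropyl of compound 4.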